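Diene geometry alone: compound 3 to compound 4

This account rests on a few compounds, and the source may have more. Where it says the series, first, only, none or still open, it means among the compounds named here.

Compound 1 `CC/C=C/C=C/CCc1cc(O)c([C@@H]2O[C@H](CO)[C@@H](O)[C@H](O)[C@H]2O)c(O)c1C(=O)OC` gives 19000 nM in a functional assay on RAW264.7 cells (Mus musculus) for inhibition, read by Griess assay, with stated times of 2 h and 12 h; on this read-out lower numbers stand for stronger inhibition and higher numbers for weaker inhibition. Compound 2 `C/C=C/C=C/CCc1cc(O)c([C@@H]2O[C@H](CO)[C@@H](O)[C@H](O)[C@H]2O)c(O)c1C(=O)OC` reaches only a limit in this assay, > 40000 nM. Compound 3 `CCC/C=C/C=C\CCc1cc(O)c([C@@H]2O[C@H](CO)[C@@H](O)[C@H](O)[C@H]2O)c(O)c1C(=O)OC` likewise reaches only a limit in this assay, > 40000 nM. From the compounds shown here alone, the steps of an at least 2.1-fold higher number from compound 1 to compound 2 (0.32 log units; beyond the scatter) and an at least 2.1-fold higher number from compound 1 to compound 3 (0.32 log units; beyond the scatter) both weaken, whereas a step that the two limits leave unreadable from compound 2 to compound 3 remains open given (the limit of > 40000 nM in this assay, at which 2 of the 3 values shown sit). Compound 4 `CCC/C=C\C=C\CCc1cc(O)c([C@@H]2O[C@H](CO)[C@@H](O)[C@H](O)[C@H]2O)c(O)c1C(=O)OC` keeps every atom of compound 3 and changes only drawn configuration: the two compounds have the same atoms and bonds and differ only in configuration as drawn: 2 of 7 stereo elements differ; a double bond is drawn E in compound 3 and Z in compound 4; a double bond is drawn Z in compound 3 and E in compound 4. For the measured compounds named here, no measured step here isolates a swap of double-bond geometry, and with compound 3 already at a limit, no step beyond the scatter can be read or expected in this assay. Compound 4 is therefore expected to show a number no higher from compound 3 to compound 4 (the limit leaves the size open). The estimate for compound 4 is 40000 nM, expected between 20000 nM and 80000 nM, most likely again as a limit.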

Compound 4, half-maximal inhibitory concentration: 14000 nM
Compound 4: middle estimate off by 2.9-fold (0.46 log units), on the high side; the measured number lies below the stated range.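

In this assay, double-bond geometry alone gives a readable change on this chain, an at least 2.8-fold lower number from compound 3 to compound 4 (0.45 log units; beyond the scatter), and no other structural change can account for it: the fact that compounds 3 and 4 differ only in the configuration as drawn. Pent-1-en-1-yl in place of prop-1-en-1-yl gives an at least 2.8-fold lower number from compound 2 to compound 4 (0.45 log units; beyond the scatter). Pent-1-en-1-yl in place of but-1-en-1-yl gives a 1.4-fold lower number from compound 1 to compound 4 (0.13 log units; within the scatter).

The step between compound 2 and compound 3 cannot be read, as both values are limits. Still open, from the compounds shown here alone, is how a carboxylic acid on the shared core, or a longer chain carrying the geometry of compound 4, would read out here.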